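Reshaping the Amide Side Chain of Compound 1

The source may hold more compounds than are shown below. What is called first, only, known or untested is meant among the compounds shown, and "the series" means these compounds.

Compound 1 `CCOc1ccccc1-c1ccc(-c2nc3cnccc3c(N[C@H](CC)C(=O)N(C)C)c2C#N)cc1` is the most lipophilic of three compounds in a physicochemical assay for lipophilicity, read by HPLC, at pH 7.5 (on this read-out lower numbers stand for lower lipophilicity and higher numbers for higher lipophilicity), where compound 1 gives 3.7. Compound 2 `CC[C@@H](Nc1c(C#N)c(-c2ccc(-c3ccccc3N(C)C)cc2)nc2cnccc12)C(N)=O` lies closest, giving 3.2, and compound 3 `CC[C@@H](Nc1c(C#N)c(-c2ccc(-c3cnccc3C)cc2)nc2cnccc12)C(N)=O` lies furthest, giving 2. For the measured compounds named here, the only single-point step measured so far, a number 1.20 log units lower from compound 2 to compound 3 (beyond the scatter), exchanges 4-methylpyridin-3-yl for 2-(dimethylamino)phenyl and leaves the side chain untouched. Going by the values given here, compound 4 `CCOc1ccccc1-c1ccc(-c2nc3cnccc3c(N[C@H](CC(C)C)C(N)=O)c2C#N)cc1` differs from compound 1 by 1-carbamoyl-3-methylbutyl in place of 1-(dimethylcarbamoyl)propyl on a nitrogen on an aromatic ring; no measured step bears on this change. The chain grows while the amide becomes a primary amide, so the expected change is no change at the digits printed from compound 1 to compound 4 (within the scatter), within the scatter. Compound 4 is therefore estimated at 3.7, ranging from 3.2 to 4.2.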

Compound 4, distribution coefficient: 3.4
The estimate for compound 4 lay 0.30 log units above the measured number; the range from low to high includes it.
By their numbers in this assay, from the lowest: compound 3; then compounds 2, 4 and 1 (each within the scatter of the next, the first and the last beyond it).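

Placing 1-carbamoyl-3-methylbutyl in place of 1-(dimethylcarbamoyl)propyl on the nitrogen gives the first measured step at this side chain: in this assay, the result is a number 0.30 log units lower from compound 1 to compound 4 (within the scatter). The two groups hold the same atoms, yet the entering group carries a hydrogen-bond donor and the leaving group none, and this read-out does not separate the two compounds. No measurement available here explains this result. Going by these compounds, the amide and the chain change together in this step, so their separate contributions remain open, as does the reading for a carboxylic acid or an amine in place of the amide.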